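This account rests on a few compounds, and the source may have more. Where it says the series, first, only, none or still open, it means among the compounds named here.

Measured compounds:
- compound 1, `CC(C)CCNC(=O)c1nc(-c2cccs2)[nH]c(=O)c1O`: "not determined" (no result reported) in an assay on isolated protein for inhibition of deoxyribonuclease-1 (Homo sapiens); a higher number here means a weaker inhibitor, a lower number a stronger inhibitor
- compound 2, `CC(=O)NCCNC(=O)c1nc(-c2cccs2)[nH]c(=O)c1O`: 62600 nM

All three compounds share the same core and differ only in the group attached to the amide-type nitrogen. For the measured compounds named here, for compound 1 no number is available in this assay, so compound 2 provides the only measured value here, and on that value compound 2 is a weak inhibitor. Compound 3, `O=C(Nc1cccnc1)c1nc(-c2cccs2)[nH]c(=O)c1O`, is the next step: pyridin-3-yl in place of 2-acetamidoethyl on an amide-type nitrogen. A chain with one hydrogen-bond donor gives way to an aromatic ring without one. Going by the values given here, the data contain no comparable step, so the size and direction of the change are unknown; a step of moderate size in either direction, or none beyond the scatter, would all be plausible. Compound 3 is therefore expected to stay weak, with a shift of about a 1.6-fold lower number from compound 2 to compound 3 (0.19 log units; within the scatter). The estimate for compound 3 is 40000 nM, expected somewhere between 8000 nM and 200000 nM.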

Compound 3, half-maximal inhibitory concentration: > 100000 nM
Compound 3: no number, only a limit; the forecaster's own chance of this, stated with the estimate: 30%; middle value at least 2.5-fold (0.39 log units) from the limit.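

In this assay, compound 3 gives > 100000 nM, which is a limit of the assay and not a number. For the compounds shown here, putting pyridin-3-yl in place of 2-acetamidoethyl on the amide-type nitrogen gives an at least 1.5-fold higher number from compound 2 to compound 3 (0.20 log units; that floor lies within the scatter), the first step that can be read at this position. It offers no sign that the aromatic ring makes a stronger inhibitor than the chain, but the true size of the change stays hidden behind the limit: the limit of > 100000 nM in this assay, at which 1 of the 3 values shown sits.

Going by these compounds, it remains open whether a phenyl ring, or a chain ending in an amine or a carboxylic acid, would give a number within the range of the assay at this nitrogen. For compound 1 the entry reads "not determined" (no result reported), so its chain cannot be compared with the other two groups.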